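The compounds below may be only part of what the source reports. "The series", "measured", "known", "first", "only" and "open" are said of these compounds alone.

The measured compounds and their values are:

Compound 1, `Cc1nc(C)c(/C=C/C(=O)/C=C/c2ccccc2O)nc1C`, gives 4780 nM.
Compound 2, `Cc1nc(C)c(/C=C/C(=O)/C=C/c2cccc(O)c2)nc1C`, gives 4300 nM.
Compound 3, `Cc1nc(C)c(/C=C/C(=O)/C=C/c2ccc(O)cc2)nc1C`, gives 4010 nM.

These three share one core and differ only in where a hydroxy group sits on the phenyl ring at the end of the chain. In a functional assay on A549 cells (Homo sapiens) for antiproliferative activity, read by MTT assay, with a stated time of 72 h (on this read-out higher numbers stand for weaker inhibition and lower numbers for stronger inhibition), compound 3 shows the lowest of the three numbers, but its neighbours lie close: a 1.1-fold lower number from compound 2 to compound 3 (0.03 log units; within the scatter), and a 1.2-fold lower number from compound 1 to compound 3 (0.08 log units; within the scatter). The remaining pair behaves the same way, a 1.1-fold lower number from compound 1 to compound 2 (0.05 log units; within the scatter). None of these steps rises above the scatter, so the three compounds cannot be ranked against one another.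

Compound 4, `COc1cc(/C=C/C(=O)/C=C/c2nc(C)c(C)nc2C)ccc1O`, has not yet been measured. The change from compound 3 is methoxy in place of hydrogen on an aromatic carbon. Among the measured compounds shown here, no measured step involves adding a methoxy group, so the three steps above bear on it only indirectly: they show that small changes on this phenyl ring have left the number essentially where it was. On that basis no step beyond the scatter is expected in this assay, in either direction. Compound 4 is therefore estimated at 3800 nM, with a range from 1900 nM to 7600 nM, which means an expected step of a 1.1-fold lower number from compound 3 to compound 4 (0.02 log units; within the scatter).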

Compound 4, half-maximal inhibitory concentration: 2190 nM
Compound 4: middle estimate off by 1.7-fold (0.24 log units), on the high side; measured number inside the range.
By their numbers in this assay, from the lowest: compounds 4, 3, 2 and 1 (each within the scatter of the next, the first and the last beyond it).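

Among the compounds shown here, the first methoxy group in this set sits on an aromatic carbon ortho to a hydroxy group and meta to a large group, and in this assay the step reads a 1.8-fold lower number from compound 3 to compound 4 (0.26 log units; within the scatter). For the compounds shown here, this shows that a group of 2 heavy atoms can take the place of hydrogen at this carbon without a step beyond the scatter, something the earlier compounds could not show, as they differ only in where a single hydroxy group sits. Nothing available here explains the size of this step or ties it to any property of the methoxy group.

As far as these compounds go, it remains open whether a different group at this carbon, such as an ethoxy group, an amine, a fluorine atom or a longer chain, would move the number beyond the scatter. Also open, from the compounds shown here alone, is how a methoxy group at this carbon behaves without the neighbouring hydroxy group, and how a methoxy group placed on another carbon of the same ring compares.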